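Cyclopropyl Amide Replacing Propanoyl on a Bicyclic Core

The source may report more compounds than this note shows. Statements on the series, on what has been measured and on what is new or still open speak of the compounds shown alone.

Measured compounds:
Compound 1 `CCC(=O)N1CC2CC(C1)N2` gives 6 nM
Compound 2 `CCCC(=O)N1CC2CC(C1)N2` gives 14 nM

Both numbers come from an assay on SH-EP1 cells for displacement of a labelled ligand from Neuronal acetylcholine receptor; alpha4/beta2 (Homo sapiens), read by scintillation counting; on this read-out higher numbers stand for weaker inhibition and lower numbers for stronger inhibition. Within the data shown here, compound 1 stands lowest of the two, and its only neighbour is compound 2, reached by a 2.3-fold higher number from compound 1 to compound 2 (0.37 log units; beyond the scatter), a step beyond the scatter but modest in size. Compound 3, `C[C@@H]1C[C@@H]1C(=O)N1CC2CC(C1)N2`, has not yet been measured in this assay. Relative to compound 1 the change is a group of 4 heavy atoms (4 carbon; one three-membered non-aromatic ring of carbon only) in place of a group of 2 heavy atoms (2 carbon; no ring), on a carbonyl carbon. Among the measured compounds shown here, the only measured step that bears on this is a 2.3-fold higher number from compound 1 to compound 2 (0.37 log units; beyond the scatter), which adds one chain carbon at the same end of the molecule and weakens binding somewhat. Compound 3 adds more carbon there, held in a small ring, so a modest step in the same weakening direction is expected: a 2.5-fold higher number from compound 1 to compound 3 (0.40 log units; beyond the scatter). Compound 3 is accordingly estimated at 15 nM, with a likely range from 5 nM to 45 nM.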

Compound 3, inhibition constant: 22 nM
Compound 3: middle estimate off by 1.5-fold (0.17 log units), on the low side; the range from low to high includes it.
By their numbers in this assay, from the lowest: compound 1; then compounds 2 and 3 (each within the scatter of the next).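

In this assay, the group holding a three-membered carbon ring on the carbonyl carbon gives a 3.7-fold higher number from compound 1 to compound 3 (0.56 log units; beyond the scatter), a modest step that shows this position accepts a ring-bearing group while the number stays in the same low range. Set against the open chain of compound 2, the same group gives a 1.6-fold higher number from compound 2 to compound 3 (0.20 log units; within the scatter), which is within the scatter, so these two compounds cannot be told apart and holding the added carbons in a ring shows no clear effect here. No measurement shown explains this result.

Still open, from the compounds shown here alone, is how a plain cyclopropyl group without the extra methyl, or a single methyl on the same carbonyl carbon, would read. The effect of the 2 defined stereocentres is also unknown, as the mirror-image form of this ring group is not among the compounds shown.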